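Methyl in place of amino on an aromatic carbon

The compounds below may be only part of what the source reports. "The series", "measured", "known", "first", "only" and "open" are said of these compounds alone.

Compound 1 `Oc1ccc(Nc2nc(-c3cccc(F)c3)nc3ccc(F)cc23)cc1` and compound 2 `Nc1cccc(Nc2nc(-c3cccc(F)c3)nc3ccc(F)cc23)c1` share the core and differ only in the group on the nitrogen. In a functional assay on MCF7 cells (Homo sapiens) for cytotoxicity, read by MTT assay, with a stated time of 48 h (a higher number here means a weaker inhibitor, a lower number a stronger inhibitor), compound 1 gives > 50000 nM as a limit of the assay. Compound 2 likewise gives > 50000 nM as a limit of the assay. The record so far is the limit of > 50000 nM in this assay, at which 2 of the 2 values shown sit, and compound 2 therefore has no number to start from.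

Compared with compound 2, compound 3 `Cc1cccc(Nc2nc(-c3cccc(F)c3)nc3ccc(F)cc23)c1` carries methyl in place of amino on an aromatic carbon, meta to a large group (methyl in place of amino on an aromatic carbon). Among the measured compounds shown here, the only measured step that bears on this is a step that the two limits leave unreadable from compound 1 to compound 2 and it offers neither a size nor a direction to carry over. No step beyond the scatter can be argued for in this assay, and another limit is the most likely report. The expected change is a number no higher from compound 2 to compound 3 (the limit leaves the size open) with no direction favoured. For compound 3 the estimated value is 50000 nM with an expected range from 15000 nM to 100000 nM around it.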

Compound 3, half-maximal inhibitory concentration: > 50000 nM
Compound 3: no number, only a limit; the forecaster's own chance of this, stated with the estimate: 75%; the middle value sits exactly at the limit.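

In this assay compound 3 gives > 50000 nM as a limit of the assay. Its steps from compound 1 and compound 2 cannot be read, so no size or direction follows for any of the three compounds. The compounds shown leave open whether any group on the nitrogen of the shared core gives a measurable value in this assay at all.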